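Moving the Furan Link in a Two-Compound Series

A few compounds are considered here, and "the series" means these few. Any claim that something is new, unique, unknown or untested is made for them only; others in the source may bear on it.

Values in a functional assay on BXPC-3 cells (Homo sapiens) for antiproliferative activity, read by sulforhodamine B assay, with a stated time of 72 h; on this read-out higher numbers stand for weaker inhibition and lower numbers for stronger inhibition:
- compound 1 `CC(C)(C)c1[nH]cnc1/C=c1\[nH]c(=O)/c(=C/c2cccc(C(=O)c3ccsc3)c2)[nH]c1=O`: 1.56 nM
- compound 2 `CC(C)(C)c1[nH]cnc1/C=c1\[nH]c(=O)/c(=C/c2cccc(C(=O)c3ccco3)c2)[nH]c1=O`: 9.23 nM

Of these two compounds, compound 2 has the higher number and is therefore the weaker inhibitor. The next compound to be tested is compound 3 `CC(C)(C)c1[nH]cnc1/C=c1\[nH]c(=O)/c(=C/c2cccc(C(=O)c3ccoc3)c2)[nH]c1=O`. Its structural change is furan-3-yl in place of furan-2-yl on a carbonyl carbon. In plain terms, furan-3-yl takes the place of furan-2-yl on a carbonyl carbon, using the same atoms joined differently.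

Within the data shown here, only one measured step bears on this change: a 5.9-fold higher number from compound 1 to compound 2 (0.77 log units; beyond the scatter). That modest step replaced thiophen-3-yl with furan-2-yl, so the ring and its point of attachment both changed at once. The data cannot separate those two changes. Furan-3-yl shares its ring type with furan-2-yl and its point of attachment with thiophen-3-yl, so compound 3 may recover part of that gap in this assay. The expected change is a modest move toward a lower number, a 2.3-fold lower number from compound 2 to compound 3 (0.36 log units; beyond the scatter), though it could stay within the scatter. For compound 3 the estimated value is 4 nM, with an expected range from 1.5 nM to 12 nM.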

Compound 3, half-maximal inhibitory concentration in the BXPC-3 assay: 9.41 nM
Compound 3: the middle estimate sits 2.4-fold (0.37 log units) below what was measured; measured number inside the range.
By their numbers in the BXPC-3 assay, from the lowest: compound 1; then compounds 2 and 3 (each within the scatter of the next).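

In the BXPC-3 assay, moving the furan's point of attachment on the carbonyl carbon makes no readable difference, a 1.0-fold higher number from compound 2 to compound 3 (0.01 log units; within the scatter), so furan-2-yl and furan-3-yl cannot be told apart at this position. The earlier step changed the ring type and the point of attachment together, whereas this pair keeps the attachment fixed and changes only the ring, a 6.0-fold higher number from compound 1 to compound 3 (0.78 log units; beyond the scatter); among these three compounds, the gap therefore goes with thiophene versus furan and not with where the furan is joined. In a physicochemical assay for solubility, read by HPLC, with a stated time of 24 h (on this read-out higher numbers stand for higher solubility and lower numbers for lower solubility), compound 2 gives < 0.1 ug/mL, which is a limit of the assay and not a number. In the physicochemical assay compound 3 gives < 0.1 ug/mL, which is also a limit of the assay and not a number. In the physicochemical assay the step between the two furans cannot be read, as both values are limits of the assay and not numbers: the limit of < 0.1 ug/mL in the physicochemical assay, at which 2 of the 2 values shown sit.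

Thiophen-2-yl would show whether the point of attachment is equally silent on the sulfur-containing ring, and this remains open. Also open, going by these compounds, is whether a phenyl ring, or a ring carrying an amine or a carboxylic acid, on the same carbonyl carbon would keep the activity of compound 1 and give a readable number in the physicochemical assay.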